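Adding a sulfamoyl group to compound 3

The source may hold more compounds than are shown below. What is called first, only, known or untested is meant among the compounds shown, and "the series" means these compounds.

Among the measured compounds shown here, in an ADME assay on MT4 cells (Homo sapiens) for cytotoxicity, read by MTT assay, with a stated time of 5 days (on this read-out higher numbers stand for lower toxicity in this test and lower numbers for higher toxicity in this test), compound 3 (`Cc1cc(C)cc(S(=O)(=O)n2c(OCC(=O)Nc3ccccc3Cl)nc3ccccc32)c1`) gives 169000 nM, the highest of the three numbers measured so far. Compound 1 (`Cc1cc(C)cc(S(=O)(=O)n2c(SCC(=O)Nc3ccccc3C(=O)O)nc3ccccc32)c1`) gives 25200 nM and compound 2 (`Cc1cc(C)cc(S(=O)(=O)n2c(SCC(=O)Nc3ccc(S(C)(=O)=O)cc3)nc3ccccc32)c1`) gives 10600 nM, and both lie below compound 3 by more than the usual scatter.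

Compound 4 (`Cc1cc(C)cc(S(=O)(=O)n2c(OCC(=O)Nc3ccc(S(N)(=O)=O)cc3Cl)nc3ccccc32)c1`) differs from compound 3 in one place, (sulfamoyl in place of hydrogen on an aromatic carbon). This is sulfamoyl in place of hydrogen on an aromatic carbon, meta to a chloro group and para to a large group, so that 2-chlorophenyl becomes 2-chloro-4-sulfamoylphenyl.

For the measured compounds named here, only one measured step bears on this change, and only indirectly: a 2.4-fold lower number from compound 1 to compound 2 (0.38 log units; beyond the scatter). There, 4-(methylsulfonyl)phenyl replaces 2-carboxyphenyl on an amide-type nitrogen. That group is not sulfamoyl, and compounds 1 and 2 also differ from compound 3 elsewhere in their structures, so the comparison is loose. Going by the values given here, no measured pair shows this exact addition.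

A modest shift towards a lower number is therefore expected, of about the size seen from compound 1 to compound 2, although no change at all remains possible. The expected move is a 2.4-fold lower number from compound 3 to compound 4 (0.38 log units; beyond the scatter). For compound 4 the estimated value is 70000 nM, with an expected range from 20000 nM to 200000 nM.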

Compound 4, half-maximal cytotoxic concentration: > 227000 nM
Compound 4: no number, only a limit; the forecaster's own chance of this, stated with the estimate: 20%; middle value at least 3.2-fold (0.51 log units) from the limit.
By their numbers in this assay, from the lowest: compound 2; then compound 1; then compound 3. At a limit, above all of these: compound 4.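

Adding sulfamoyl to this aromatic carbon, meta to a chloro group and para to a large group, gives an at least 1.3-fold higher number from compound 3 to compound 4 (0.12 log units; that floor lies within the scatter). Compound 4 therefore shows no fall in the number at this position, unlike a 2.4-fold lower number from compound 1 to compound 2 (0.38 log units; beyond the scatter), although that step involved a different group and a different starting compound. The reading for compound 4 is a limit of the assay and not a number, so the step has only a floor, and that floor alone does not establish a real rise over compound 3: the limit of > 227000 nM in this assay, at which 1 of the 4 values shown sits.

From the compounds shown here alone, how far the true value of compound 4 lies past this limit stays open, and so does whether the addition changes the number by more than the usual scatter in this assay. The compounds shown also do not tell whether an amine, a carboxylic acid or a methylsulfonyl group on the same aromatic carbon would behave like sulfamoyl, or whether sulfamoyl would give the same result on a phenyl ring without the chloro group.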